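The source may report more compounds than this note shows. Statements on the series, on what has been measured and on what is new or still open speak of the compounds shown alone.

Measured so far:
- compound 1 `CCOC(=O)CCO/N=C(/c1ccc(OC)c(OC)c1OC)c1cccc2ccccc12`: 19600 nM
- compound 3 `COc1ccc(/C(=C/c2ccc(F)cc2)c2cccc3ccccc23)c(OC)c1OC`: 18600 nM
- compound 2 `COc1ccc(C(c2ccc(OCCO)cc2)c2cccc3ccccc23)c(OC)c1OC`: a limit, > 20000 nM

In a functional assay on A549 cells (Homo sapiens) for inhibition, read by sulforhodamine B assay, with a stated time of 48 h (a lower number here means a stronger inhibitor, a higher number a weaker inhibitor), compound 1 gives 19600 nM. Compound 3 gives 18600 nM in this assay, and the two numbers lie within the scatter of each other, so no order between compound 1 and compound 3 is claimed. For compound 2 this assay reports only a limit, > 20000 nM. All three results therefore sit at the weak end of the measured range, and one of them is a limit rather than a number, as noted in the limit of > 20000 nM in this assay, at which 1 of the 3 values shown sits.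

For the measured compounds named here, no single-point step between measured compounds is available. Compound 4 `COc1ccc(/C(=N/OCC(=O)O)c2cccc3ccccc23)c(OC)c1OC` is not yet measured in this assay. It differs from compound 1 by carboxy in place of (ethoxycarbonyl)methyl on a saturated chain carbon bound to an oxygen on an unsaturated carbon. With compound 1 already at 19600 nM, its number sits toward the weak end of the measured range. The expected step from compound 1 to compound 4 is a 1.3-fold higher number from compound 1 to compound 4 (0.11 log units; within the scatter), not beyond the scatter. Compound 4 is estimated at 25000 nM, with a range of 9000 nM to 70000 nM, and a real chance that only a limit is returned.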

Compound 4, half-maximal inhibitory concentration: 17200 nM
Estimate against measurement, compound 4: 1.5-fold (0.16 log units) above; the range from low to high includes it.
By their numbers in this assay, from the lowest: compounds 4, 3 and 1 (each within the scatter of the next). At a limit, above all of these: compound 2.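

In this assay, carboxy in place of (ethoxycarbonyl)methyl on a saturated chain carbon bound to an oxygen on an unsaturated carbon gives a 1.1-fold lower number from compound 1 to compound 4 (0.06 log units; within the scatter), so this large change at this position leaves no readable difference in the number. For the compounds shown here, this is the only single-point step so far, and it shows that the ester end of the chain can be cut back to carboxymethyl without a shift beyond the scatter. Both compounds lie at the weak end of the range, where compound 2 is a limit and not a number: the limit of > 20000 nM in this assay, at which 1 of the 4 values shown sits.

As far as these compounds go, whether an amine, a primary amide or a longer chain ending in a carboxylic acid at this position would move the number beyond the scatter stays open. Also open, from the compounds shown here alone, is whether this step would stay as small on a compound with a much lower number.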